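The source may report more compounds than this note shows. Statements on the series, on what has been measured and on what is new or still open speak of the compounds shown alone.

In an ADME assay on J774 cells (Mus musculus) for cytotoxicity (on this read-out lower numbers stand for an effect already at smaller amounts and higher numbers for an effect only at larger amounts of compound), compound 1 (`CCCCc1cc2c(=O)c(C(=O)OCC)c[nH]c2cc1OCCOc1ccccc1`) gives > 20000 nM, which is a limit of the assay and not a number. Compound 2 (`CCCCc1cc2c(=O)c(C(=O)NCCO)c[nH]c2cc1OCCOc1ccccc1`) gives > 20000 nM, again a limit and not a number. Compound 2 therefore stands at the limit of > 20000 nM in this assay, at which 2 of the 2 values shown sit.

Compound 3 (`CCCCc1cc2c(=O)c(I)c[nH]c2cc1OCCOc1ccccc1`) differs from compound 2 in one place: iodo in place of (2-hydroxyethyl)carbamoyl on an aromatic carbon. Iodo thus takes the place of (2-hydroxyethyl)carbamoyl on an aromatic carbon.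

Among the compounds with values here, only one measured step bears on this change: a step that the two limits leave unreadable from compound 1 to compound 2. That step altered the group on the same aromatic carbon, but it has no readable size, so it offers no measured guide to how far a change here can move this assay. The replacement in compound 3 is also a larger one, so some shift towards lower numbers cannot be ruled out. Still, the expectation rests on compound 1 and compound 2, which share (the limit of > 20000 nM in this assay, at which 2 of the 2 values shown sit), and it points to little or no change.

The expected step is a number no higher from compound 2 to compound 3 (the limit leaves the size open).

For compound 3 the estimated value is 20000 nM, with an expected range from 7000 nM to 40000 nM.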

Compound 3, half-maximal effective concentration: > 10000 nM
Compound 3: a limit, no number (the forecaster's own chance of this, stated with the estimate: 65%); the middle value does not contradict the limit.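

In this assay compound 3 gives > 10000 nM, which is a limit of the assay and not a number. Within the data shown here, compound 1, compound 2 and compound 3 all sit at limits, so no step among them can be read. The compounds shown leave open whether exchanging the group on this aromatic carbon changes the result in this assay at all.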